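Fluoro for sulfamoyl on the anilino ring of compound 1

The source may hold more compounds than are shown below. What is called first, only, known or untested is meant among the compounds shown, and "the series" means these compounds.

Compound 1 `NS(=O)(=O)c1ccc(Nc2nncc3ccccc23)cc1` is the parent of the set. In a functional assay on HL-60 cells (Homo sapiens) for antiproliferative activity, read by sulforhodamine B assay, with a stated time of 72 h (on this read-out higher numbers stand for weaker inhibition and lower numbers for stronger inhibition), compound 1 gives 18 nM, the lowest number of the three measured. Compound 2 `O=S(=O)(Nc1nccs1)c1ccc(Nc2nncc3ccccc23)cc1` gives 77 nM and compound 3 `O=S(=O)(Nc1ncccn1)c1ccc(Nc2nncc3ccccc23)cc1` gives 67 nM. Both measured steps run in the same direction: a 4.3-fold higher number from compound 1 to compound 2 (0.63 log units; beyond the scatter) and a 3.7-fold higher number from compound 1 to compound 3 (0.57 log units; beyond the scatter), while a 1.1-fold lower number from compound 2 to compound 3 (0.06 log units; within the scatter) separates compounds 2 and 3 by nothing beyond the scatter.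

Compound 4 `Fc1ccc(Nc2nncc3ccccc23)cc1` differs from compound 1 as follows: fluoro in place of sulfamoyl on an aromatic carbon. Among the measured compounds shown here, the measured steps only alter what sits on the sulfonamide nitrogen; none removes the sulfamoyl group itself, so no step bears directly on this change. For the measured compounds named here, the data show that any alteration at this position so far has raised the number modestly, and a complete replacement is expected to move the number at least as far, with a wide spread. Compound 4 is therefore expected to show an 11-fold higher number from compound 1 to compound 4 (1.05 log units; beyond the scatter), giving an estimated 200 nM with a range from 40 nM to 1500 nM.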

Compound 4, half-maximal inhibitory concentration: 6.4 nM
For compound 4 the middle estimate is 31-fold (1.49 log units) above the measured one; measured number outside the range, below it.
By their numbers in this assay, from the lowest: compound 4; then compound 1; then compounds 3 and 2 (each within the scatter of the next).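

In this assay, replacing the whole sulfamoyl group with fluoro on this aromatic carbon does not weaken the read-out, but gives a 2.8-fold lower number from compound 1 to compound 4 (0.45 log units; beyond the scatter). The earlier steps shown here changed only the sulfonamide nitrogen and raised the number, so they left open whether the sulfamoyl group itself was needed for a low number; here the hydrogen-bond donor and acceptors of that group prove unnecessary for one. No measurement on hand accounts for this step.

On these data alone, it remains open whether the lower number belongs to fluoro itself or simply to the loss of sulfamoyl. A chloro, methoxy, amine or carboxylic acid group on the same aromatic carbon, or a plain hydrogen there, would help separate these two readings.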